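A few compounds are considered here, and "the series" means these few. Any claim that something is new, unique, unknown or untested is made for them only; others in the source may bear on it.

Working notes on the series in a functional assay on HeLa cells (Homo sapiens) for inhibition, read by sulforhodamine B assay, with a stated time of 48 h; a lower number here means a stronger inhibitor of growth, a higher number a weaker inhibitor of growth. Of the compounds shown here, three have numbers so far. Compound 1 `O=C(/C=C/C1CCCCC1)c1ccccc1` gives 21000 nM in this assay. Compound 2 `O=C(/C(=C/c1ccccc1)CCl)c1ccccc1` gives 23000 nM, and compound 3 `O=C(/C(=C/c1ccc(Cl)cc1)CCl)c1ccccc1` gives 22000 nM. On these three numbers compound 3 stands second highest, with compound 2 nearest and compound 1 furthest, and both gaps lie within the scatter, so the three compounds cannot be ordered against one another. Within the data shown here, the only step between measured compounds that differ in one place is a 1.0-fold lower number from compound 2 to compound 3 (0.02 log units; within the scatter), a chloro in place of hydrogen on an aromatic carbon.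

Compound 4 `O=C(/C(=C/c1ccc(Cl)cc1Cl)CCl)c1ccccc1` is the next compound, not yet measured. It differs from compound 3 by chloro in place of hydrogen on an aromatic carbon. Among the measured compounds shown here, the one measured step that bears on this change, a 1.0-fold lower number from compound 2 to compound 3 (0.02 log units; within the scatter), was within the scatter, so no step beyond the scatter is expected in this assay in either direction. Compound 4 is therefore expected to give 22000 nM, with a range from 10000 nM to 45000 nM. The expected step is no change at the digits printed from compound 3 to compound 4 (within the scatter).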

Compound 4, concentration for 50% growth inhibition: 15000 nM
Compound 4: the middle estimate sits 1.5-fold (0.17 log units) above what was measured, within the range that was stated.
By their numbers in this assay, from the lowest: compounds 4, 1, 3 and 2 (each within the scatter of the next).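

In this assay a second chloro, here on a six-membered aromatic ring of carbon only, ortho to a large group and meta to a chloro group, gives a 1.5-fold lower number from compound 3 to compound 4 (0.17 log units; within the scatter) and so stays within the scatter at this new place. Read with the first chloro on the same ring, which gave a 1.0-fold lower number from compound 2 to compound 3 (0.02 log units; within the scatter), neither of the two steps lifts a compound clear of the scatter, and the series has no chloro step yet that can be read as a real difference. No measurement at hand bears on the reason for the size of this step.

Still open, as far as these compounds go, is whether any other group at this ortho place, such as an amine, a methoxy group or a carboxylic acid, would give a step beyond the scatter. Also open, from the compounds shown here alone, is whether a longer chain in place of the chloromethyl group would do so.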